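Methoxy for methyl: a small change on the anilino ring

The source may report more compounds than this note shows. Statements on the series, on what has been measured and on what is new or still open speak of the compounds shown alone.

Three analogues share one core. In a functional assay on the whole organism (strain albino) with Mus musculus as the target, in the maximal electroshock model, with a stated time of 0.5 h (a lower number here means that less compound is needed, a higher number that more compound is needed for the effect), compound 1 `COc1ccccc1Nc1nnc(Nc2nc(-c3ccc(Br)cc3)cs2)s1` gives 300 mg/kg, and compound 2 `COc1ccccc1Nc1nnc(Nc2nc(-c3ccc([N+](=O)[O-])cc3)cs2)s1` gives 300 mg/kg. Going by the values given here, the step of no change at the digits printed from compound 1 to compound 2 (within the scatter) is the only measured step. Compound 3 `Cc1ccccc1Nc1nnc(Nc2nc(-c3ccccc3)cs2)s1` stands level with both of them, giving 300 mg/kg in this assay. Compound 4 `COc1ccccc1Nc1nnc(Nc2nc(-c3ccccc3)cs2)s1` has not been measured; it differs from compound 3 by methoxy in place of methyl on an aromatic carbon. Among the compounds with values here, no measured step touches this position, so nothing among the measured compounds points in either direction; the one step, from nitro to bromo on a different ring, showed no change. The expected step of no change at the digits printed from compound 3 to compound 4 (within the scatter) is therefore none beyond the scatter. Compound 4 is estimated at 300 mg/kg, within the range 100 mg/kg to 600 mg/kg.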

Compound 4, minimum effective dose: 100 mg/kg
The estimate for compound 4 lay 3.0-fold (0.48 log units) above the measured number; the measured number falls inside the stated range.
By their numbers in this assay, from the lowest: compound 4; then compounds 1, 2 and 3 (each within the scatter of the next).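

In this assay, methoxy in place of methyl on this aromatic carbon, ortho to a large group, gives a 3.0-fold lower number from compound 3 to compound 4 (0.48 log units; beyond the scatter), so this position responds to the change. With methoxy held, hydrogen in place of nitro gives a 3.0-fold lower number from compound 2 to compound 4 (0.48 log units; beyond the scatter) and hydrogen in place of bromo gives a 3.0-fold lower number from compound 1 to compound 4 (0.48 log units; beyond the scatter), so the para-free compound 4 stands apart from two substituted analogues that had looked alike. Nothing available explains these steps. As far as these compounds go, whether an ethoxy group or an amine on this carbon would lower the number further remains open, as does whether hydrogen in place of bromo would give the same step with methyl kept.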